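A few compounds are considered here, and "the series" means these few. Any claim that something is new, unique, unknown or untested is made for them only; others in the source may bear on it.

Compound 1 `CNC(=O)c1cc(C(=O)NC2CC2)cn(Cc2ccc(OC)cc2)c1=O` has been tested in a physicochemical assay for solubility; on this read-out lower numbers stand for lower solubility and higher numbers for higher solubility. In this assay compound 1 gives >= 143 ug/mL, which is a limit of the assay rather than a number (the limit of >= 143 ug/mL in this assay, at which 1 of the 3 values shown sits). Compound 4 `CNC(=O)c1cc(C(=O)NC2CC2)cn(CC2CCCCC2)c1=O` has not yet been measured and differs from compound 1 in a single place: cyclohexyl in place of 4-methoxyphenyl on a saturated chain carbon bound to an aromatic nitrogen. The nearest measured comparison comes from compound 2 `CNC(=O)c1cc(C(=O)NCCOC)cn(Cc2ccccc2)c1=O` and compound 3 `CNC(=O)c1cc(C(=O)NCCC(C)C)cn(Cc2ccccc2)c1=O`. In this assay compound 2 gives >= 164 ug/mL, again a limit of the assay (the limit of >= 164 ug/mL in this assay, at which 1 of the 3 values shown sits). In this assay compound 3 gives 10 ug/mL. That step, an at least 16-fold lower number from compound 2 to compound 3 (1.21 log units; beyond the scatter), likewise removed a methoxy in favour of a saturated carbon group. A drop is therefore expected for compound 4, an at least 4.7-fold lower number from compound 1 to compound 4 (0.67 log units; beyond the scatter), to an estimated 30 ug/mL, with a range from 8 ug/mL to 120 ug/mL.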

Compound 4, solubility: >= 148 ug/mL
Compound 4 ended at the assay's limit; the forecaster's own chance of this, stated with the estimate: 15%; middle value at least 4.9-fold (0.69 log units) from the limit.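

Compound 1 and compound 4 each gave a limit of this assay rather than a number, and the step between them cannot be read. The compounds shown leave open whether cyclohexyl in place of 4-methoxyphenyl changes this read-out at all.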